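Chloro in place of methoxy on the distal ring

A few compounds are considered here, and "the series" means these few. Any claim that something is new, unique, unknown or untested is made for them only; others in the source may bear on it.

In an ADME assay on HeLa Rh cells (Homo sapiens) for cytotoxicity, read by microscopy (on this read-out higher numbers stand for lower toxicity in this test and lower numbers for higher toxicity in this test), the three measured compounds stand as follows.
Compound 1, `COc1cc(CC(O)c2ccc(-c3ccc(C#N)cc3)cc2)c([N+](=O)[O-])cc1OC`: 4700 nM.
Compound 2, `COc1cc(CC(O)c2ccc(-c3ccc(C=O)cc3)cc2)c([N+](=O)[O-])cc1OC`: > 245000 nM, which is a limit of this assay and not a number.
Compound 3, `COc1ccc(-c2ccc(C(O)Cc3cc(OC)c(OC)cc3[N+](=O)[O-])cc2)cc1`: > 244000 nM, likewise a limit of this assay and not a number.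

Among the compounds with values here, compound 3 therefore holds no readable number; its only anchor is the step of an at least 51-fold higher number from compound 1 to compound 3 (1.71 log units; beyond the scatter). Compound 4, `COc1cc(CC(O)c2ccc(-c3ccc(Cl)cc3)cc2)c([N+](=O)[O-])cc1OC`, differs from it by chloro in place of methoxy on an aromatic carbon. Within the data shown here, two measured steps touch the same ring position: an at least 51-fold higher number from compound 1 to compound 3 (1.71 log units; beyond the scatter) and an at least 52-fold higher number from compound 1 to compound 2 (1.71 log units; beyond the scatter), both large, while a step that the two limits leave unreadable from compound 2 to compound 3. Nothing shows whether chloro behaves like cyano or like methoxy here, so for compound 4 a step back toward lower numbers is taken as possible but unproven: the estimate is an at least 3.0-fold lower number from compound 3 to compound 4 (0.48 log units; beyond the scatter). Compound 4 is accordingly expected at 80000 nM, within 10000 nM to 245000 nM.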

Compound 4, half-maximal cytotoxic concentration: 4100 nM
Beside the measured number, compound 4's estimate is 20-fold (1.29 log units) above it; the measured number lies below the stated range.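

In this assay, chloro falls with cyano and not with methoxy or formyl at this position: a 1.1-fold lower number from compound 1 to compound 4 (0.06 log units; within the scatter), against an at least 59-fold lower number from compound 3 to compound 4 (1.77 log units; beyond the scatter) and an at least 59-fold lower number from compound 2 to compound 4 (1.77 log units; beyond the scatter). Low numbers here are therefore not tied to the nitrile alone, and the four compounds fall into two sets, compound 1 with compound 4 and compound 2 with compound 3. Compound 3 holds a limit and not a number: the limit of > 244000 nM in this assay, at which 1 of the 4 values shown sits.

Going by these compounds, what separates chloro and cyano from methoxy and formyl stays open. So does how an amine, a carboxylic acid or a fluoro group would read at this position.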